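The compounds below may be only part of what the source reports. "The series", "measured", "known", "first", "only" and "open" are said of these compounds alone.

Measured in a functional assay on MCF7 cells (Homo sapiens) for cytotoxicity, read by MTT assay, with a stated time of 96 h; a lower number here means a stronger inhibitor, a higher number a weaker inhibitor:
Compound 1 `COc1cc(C(=O)c2cn(-c3ccc([N+](=O)[O-])cc3)cc2-c2ccccc2)cc(OC)c1OC`: 4000 nM
Compound 2 `COc1cc(C(=O)c2cn(-c3ccccc3)cc2-c2cccc(Br)c2)cc(OC)c1OC`: 950 nM

Compound 2 holds the lower of the two numbers, and its gap to compound 1 lies beyond the scatter. Compound 3 `COc1ccccc1-c1cn(-c2ccccc2)cc1C(=O)c1cc(OC)c(OC)c(OC)c1` is not yet measured in this assay. It carries 2-methoxyphenyl in place of 3-bromophenyl on an aromatic carbon. Within the data shown here, no measured pair isolates a change at this place, so the expectation is anchored on compound 2 at 950 nM. As far as these compounds go, no change beyond the scatter is expected, and the direction stays open: the expected step is a 1.4-fold lower number from compound 2 to compound 3 (0.13 log units; within the scatter). For compound 3 the estimated value is 700 nM, with an expected range of 170 nM to 2800 nM.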

Compound 3, half-maximal inhibitory concentration: 190 nM
Estimate against measurement, compound 3: 3.7-fold (0.57 log units) above, within the range that was stated.
By their numbers in this assay, from the lowest: compound 3; then compound 2; then compound 1.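

In this assay, among these compounds, this aromatic carbon of the five-membered ring gives the first single-place step: 2-methoxyphenyl in place of 3-bromophenyl gives a 5.0-fold lower number from compound 2 to compound 3 (0.70 log units; beyond the scatter). The result is therefore sensitive to the phenyl group carried here. That step changes both the substituent and its location on the phenyl ring, and nothing measured here accounts for it.

As far as these compounds go, it remains open whether the substituent or its location drives the step, which 2-bromophenyl or 3-methoxyphenyl could separate. Also open, from the compounds shown here alone, is how an aminophenyl group would compare at this place.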